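The source may report more compounds than this note shows. Statements on the series, on what has been measured and on what is new or still open speak of the compounds shown alone.

Measured compounds:
Compound 1, `CCCCCCNc1cncc(C(=O)NCc2ccccc2)n1`, gives 100000 nM in an ADME assay on Vero cells (Chlorocebus sabaeus) for cytotoxicity, read by microscopy, with a stated time of 6 days; on this read-out higher numbers stand for lower toxicity in this test and lower numbers for higher toxicity in this test.
Compound 2, `CCCCCCCNc1nccnc1C(=O)NCc1ccccc1`, gives only a limit of the assay, > 100000 nM.
Compound 3, `CCCCCNc1nccnc1C(=O)NCc1ccccc1`, likewise gives only a limit of the assay, > 100000 nM.

Compound 4, `CCCCNc1cncc(C(=O)NCc2ccccc2)n1`, has not yet been measured. It differs from compound 1 by hydrogen in place of ethyl on a saturated chain carbon, four bonds along the chain from a nitrogen on an aromatic ring. The same kind of change separates compound 2 from compound 3, namely (hydrogen in place of ethyl on a saturated chain carbon, five bonds along the chain from a nitrogen on an aromatic ring); the place is not the same, one change sitting four bonds along the chain from the ring nitrogen and the other five bonds along it. The step for that pair, a step that the two limits leave unreadable from compound 2 to compound 3, cannot be read because of the limit of > 100000 nM in this assay, at which 2 of the 3 values shown sit. How the core of compound 1 differs from that of compound 2 is not broken down here.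

For the measured compounds named here, for compound 4 the step from compound 1 is expected to be small, no change at the digits printed from compound 1 to compound 4 (within the scatter), since compound 1 gives 100000 nM and the only comparable pair leaves its step unreadable. Compound 4 is therefore estimated at 100000 nM, with a range from 50000 nM to 200000 nM.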

Compound 4, minimum cytotoxic concentration: 100000 nM
For compound 4 middle estimate and measured number coincide at the digits printed; the measured number falls inside the stated range.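

In this assay, putting hydrogen in place of ethyl on a saturated chain carbon, four bonds along the chain from a nitrogen on an aromatic ring, gives no change at the digits printed from compound 1 to compound 4 (within the scatter). This shows that, on the core of compound 1, this shortening of the chain leaves the reading within the scatter, but it is a single step on a single core. It does not show that the change carries over to the core of compound 2, where the closest matching change sits five bonds along the chain and its step cannot be read because compound 2 and compound 3 each give only a limit: the limit of > 100000 nM in this assay, at which 2 of the 4 values shown sit.

The compounds shown leave open what a carboxylic acid or an amine at the end of the chain would do in this assay. They also leave open whether a longer chain on the core of compound 1 would move the reading beyond the scatter.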